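The compounds below may be only part of what the source reports. "The series", "measured", "known", "first", "only" and "open" are said of these compounds alone.

Three compounds sharing one core were compared in an ADME assay on HepG2 2.2.15 cells (Homo sapiens) for cytotoxicity, read by MTT assay, with stated times of 48 h and 9 days; a higher number here means that more compound is tolerated, a lower number that less compound is tolerated. Compound 1 `COc1ccc(CNC(=O)/C=C/c2coc3cc(OC)ccc3c2=O)cc1` gives 43000 nM, compound 2 `COc1ccc2c(=O)c(/C=C/C(=O)NCc3ccc(C)cc3)coc2c1` gives 257000 nM, and compound 3 `COc1cccc(NC(=O)/C=C/c2coc3cc(OC)ccc3c2=O)c1` gives 1130000 nM. Compound 3 thus stands highest of the three numbers: the step of a 4.4-fold higher number from compound 2 to compound 3 (0.64 log units; beyond the scatter) is modest and the step of a 26-fold higher number from compound 1 to compound 3 (1.42 log units; beyond the scatter) is large, so compound 3 is the best tolerated of the set in this assay.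

Compound 4 `COc1ccc2c(=O)c(/C=C/C(=O)NCc3ccc(F)cc3F)coc2c1` differs from compound 3 in one place: 2,4-difluorobenzyl in place of 3-methoxyphenyl on an amide-type nitrogen. Two of the measured steps bear on this change, a 26-fold higher number from compound 1 to compound 3 (1.42 log units; beyond the scatter) and a 4.4-fold higher number from compound 2 to compound 3 (0.64 log units; beyond the scatter), both of which put 3-methoxyphenyl in place of 4-methoxybenzyl or 4-methylbenzyl on the amide nitrogen. For the measured compounds named here, compound 4 reverses that direction, returning to a benzyl group, now 2,4-difluorobenzyl, and no measured pair shows what the fluorine substitution does. The two benzyl compounds also differ from each other, as the step of a 6.0-fold higher number from compound 1 to compound 2 (0.78 log units; beyond the scatter) shows, so the size of the expected fall is uncertain. In this assay a step of a 9.4-fold lower number from compound 3 to compound 4 (0.97 log units; beyond the scatter) is therefore expected, a drop beyond the scatter. For compound 4 the estimated value is 120000 nM, with a range from 30000 nM to 500000 nM.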

Compound 4, half-maximal cytotoxic concentration: 79300 nM
Beside the measured number, compound 4's estimate is 1.5-fold (0.18 log units) above it; the measured number falls inside the stated range.
By their numbers in this assay, from the lowest: compounds 1 and 4 (each within the scatter of the next); then compound 2; then compound 3.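

In this assay, the 2,4-difluorobenzyl group on the amide-type nitrogen stands far from the 3-methoxyphenyl group, with a 14-fold lower number from compound 3 to compound 4 (1.15 log units; beyond the scatter), so a third benzyl compound now lies well under compound 3. The substituents on the benzyl ring still separate some compounds but not others: a 3.2-fold lower number from compound 2 to compound 4 (0.51 log units; beyond the scatter) is a real difference, whereas a 1.8-fold higher number from compound 1 to compound 4 (0.27 log units; within the scatter) leaves these two compounds indistinguishable in this assay. Fluorine at both printed ring positions therefore does not match the value of the 4-methylbenzyl compound, and it gives a number that cannot be told apart from that of the 4-methoxybenzyl compound, while all three benzyl compounds remain under compound 3.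

No measurement offered here accounts for these differences. Compound 3 differs from the benzyl compounds both in lacking the saturated chain carbon and in its ring substituent, so the compounds shown leave open how far each contributes, a question that a 3-methoxybenzyl group or a 4-methoxyphenyl group on the same nitrogen could help to separate.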